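Nitro added to a chloropyridine amide of a benzothiazole aniline

The source may report more compounds than this note shows. Statements on the series, on what has been measured and on what is new or still open speak of the compounds shown alone.

Compound 1 `O=C(Nc1cccc(-c2nc3ccccc3s2)c1)c1cccnc1Cl` — in an ADME assay on HEK293 cells (Homo sapiens) for inhibition, with a stated time of 72 h (on this read-out higher numbers stand for an effect only at larger amounts of compound and lower numbers for an effect already at smaller amounts), compound 1 gives > 25000 nM, a limit of the assay.
Compound 2 `O=C(Nc1cccc(-c2nc3ccccc3s2)c1)c1ccncc1Cl` — in this assay compound 2 gives > 25000 nM, likewise a limit of the assay.

Compound 1 stands only at a limit; no number is known for it in this assay. Among the measured compounds shown here, the single measured step, a step that the two limits leave unreadable from compound 1 to compound 2, cannot be read, since (the limit of > 25000 nM in this assay, at which 2 of the 2 values shown sit). Compound 3 `O=C(Nc1cccc(-c2nc3ccccc3s2)c1)c1cc([N+](=O)[O-])cnc1Cl` is built from compound 1 by a change in which (nitro in place of hydrogen on an aromatic carbon). For the measured compounds named here, no measured step bears directly on this change, and the one step that exists is unreadable; the only guide is that the two related compounds both sit at the limit. Compound 1 gives no reading in this assay, and the added nitro group is a small change to the same core, so compound 3 is expected to remain at or near the limit as well. Compound 3 is therefore estimated at 30000 nM, within a range from 8000 nM to 100000 nM. The expected step is a step that the limit leaves unreadable from compound 1 to compound 3, meaning no change beyond the scatter is anticipated.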

Compound 3, half-maximal effective concentration: > 25000 nM
Compound 3 ended at the assay's limit; the forecaster's own chance of this, stated with the estimate: 80%; the middle value lies beyond the limit too.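

Among the compounds shown here, compound 3 stands at a limit, as compound 1 does, so no step between compound 1 and compound 3 can be read: the limit of > 25000 nM in this assay, at which 3 of the 3 values shown sit.

The compounds shown leave open whether any change to the shared core brings a measurable value in this assay and what size of effect the nitro group has there.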